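This account rests on a few compounds, and the source may have more. Where it says the series, first, only, none or still open, it means among the compounds named here.

Compound 1 `Cc1cc(Nc2ccn(Cc3ccccc3)n2)n2nc(SCc3ccc(Br)cc3)nc2n1`: > 50000 nM (a limit)
Compound 2 `Cc1cc(Nc2ccn(Cc3ccc(F)cc3)n2)n2nc(SCc3ccc(Br)cc3)nc2n1`: 19400 nM

Both compounds were tested in a functional assay on PC-9 cells (Homo sapiens) for inhibition, read by MTT assay, with a stated time of 72 h; on this read-out lower numbers stand for stronger inhibition and higher numbers for weaker inhibition. Compound 1 gives > 50000 nM, which is a limit and not a number. Going by the values given here, compound 2, at 19400 nM, holds the only actual number so far.

Compound 3 `Cc1cc(Nc2ccn(Cc3csc4ccc(Cl)cc34)n2)n2nc(SCc3ccc(Br)cc3)nc2n1` has not yet been measured. It differs from compound 2 as follows: 5-chloro-1-benzothiophen-3-yl in place of 4-fluorophenyl on a saturated chain carbon bound to an aromatic nitrogen. In words, 5-chloro-1-benzothiophen-3-yl stands in place of 4-fluorophenyl on a saturated chain carbon bound to an aromatic nitrogen.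

Among the compounds with values here, one measured step bears on this change, as it alters the same group: an at least 2.5-fold lower number from compound 1 to compound 2 (0.41 log units; beyond the scatter). This single step is modest and only loosely related to the larger exchange, so a modest further fall in the number is expected in this assay. For compound 3, the estimated value is 10000 nM, with an expected range from 2500 nM to 40000 nM. The expected change is a 1.9-fold lower number from compound 2 to compound 3 (0.29 log units; within the scatter).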

Compound 3, half-maximal inhibitory concentration: 4350 nM
Estimate against measurement, compound 3: 2.3-fold (0.36 log units) above; the measured number falls inside the stated range.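

In this assay, the place on a saturated chain carbon bound to an aromatic nitrogen accepts far more than a fluoro exchange on the phenyl ring: 5-chloro-1-benzothiophen-3-yl, with its two aromatic rings, gives a 4.5-fold lower number from compound 2 to compound 3 (0.65 log units; beyond the scatter). Set against plain phenyl, the same group gives an at least 11-fold lower number from compound 1 to compound 3 (1.06 log units; beyond the scatter), the largest step seen at this place so far. The true size of that step stays unknown, as compound 1 sits at a limit and not at a number: the limit of > 50000 nM in this assay, at which 1 of the 3 values shown sits.

The compounds shown change the chlorine and the fused ring together, so they do not separate the two, and neither 4-chlorophenyl nor the unsubstituted 1-benzothiophen-3-yl group is among them. From the compounds shown here alone, how a naphthyl group or a basic amine would fare at this place also remains open.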